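Pyridine-carboximidamide thiosemicarbazides: morpholine versus piperidine

The source may report more compounds than this note shows. Statements on the series, on what has been measured and on what is new or still open speak of the compounds shown alone.

Compound 1 `N/C(=N\NC(=S)N1CCOCC1)c1ccccn1` carries a morpholin-4-yl ring on the thiocarbonyl carbon. In a functional assay on MCF7 cells (Homo sapiens) for cytotoxicity, read by MTT assay, with a stated time of 72 h, tested at 30 uM (a lower number here means less inhibition of growth, a higher number more inhibition of growth at the concentration tested), compound 1 gives 78.1%. Compound 2 `N/C(=N\NC(=S)N1CCCCC1)c1ccccn1` differs by piperidin-1-yl in place of morpholin-4-yl on a thiocarbonyl carbon. In this assay compound 2 gives 69.3%, a step of a number 8.8 percentage points lower from compound 1 to compound 2 (within the scatter). Compound 3 `Cc1cccc(/C(N)=N/NC(=S)N2CCOCC2)n1` keeps the morpholin-4-yl ring and differs from compound 1 by methyl in place of hydrogen on an aromatic carbon. In this assay compound 3 gives 57.8%, a step of a number 20.3 percentage points lower from compound 1 to compound 3 (beyond the scatter), and this is the lowest number among the three measured compounds, its gaps to compound 1 and to compound 2 both lying beyond the scatter.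

Compound 4 `Cc1cccc(/C(N)=N/NC(=S)N2CCCCC2)n1` is not yet measured. It differs from compound 3 by piperidin-1-yl in place of morpholin-4-yl on a thiocarbonyl carbon. This is the same change as that from compound 1 to compound 2, made on the same place on the thiocarbonyl carbon, and it occurs twice among these compounds. Among the compounds with values here, the only measured instance, a number 8.8 percentage points lower from compound 1 to compound 2 (within the scatter), fell within the scatter.

The step from compound 3 to compound 4 in this assay is expected to be a number 7.8 percentage points lower from compound 3 to compound 4 (within the scatter), resting on the earlier instance because a number 8.8 percentage points lower from compound 1 to compound 2 (within the scatter) was small. Compound 4 in this assay is therefore estimated at 50%, with a range from 38% to 62%.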

Compound 4, percent growth inhibition at one concentration: 43%
Beside the measured number, compound 4's estimate is 7 percentage points above it; the range from low to high includes it.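

In this assay, piperidin-1-yl in place of morpholin-4-yl on a thiocarbonyl carbon gives a number 14.8 percentage points lower from compound 3 to compound 4 (beyond the scatter), and the two instances of this change do not differ: the same change on two cores in this assay, a number 8.8 percentage points lower (within the scatter) from compound 1 to compound 2 and a number 14.8 percentage points lower (beyond the scatter) from compound 3 to compound 4, 6 percentage points apart, within the scatter of two such steps. Methyl in place of hydrogen on an aromatic carbon gives a number 26.3 percentage points lower from compound 2 to compound 4 (beyond the scatter), and this change also carries from one core to the other without a difference between its instances: the same change on two cores in this assay, a number 20.3 percentage points lower (beyond the scatter) from compound 1 to compound 3 and a number 26.3 percentage points lower (beyond the scatter) from compound 2 to compound 4, 6 percentage points apart, within the scatter of two such steps. Within these four compounds the two changes therefore behave as roughly additive, but each rests on a single pair of instances in one assay at one concentration, only one of the two ring-change steps stands beyond the scatter on its own, and nothing here shows that the agreement extends to other cores or explains why either change lowers the number.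

Still open, from the compounds shown here alone, is whether other groups on the thiocarbonyl carbon, such as a dimethylamino group or a piperazin-1-yl ring, would fit the same pattern, and whether an ethyl or a methoxy group in place of the methyl would give a similar step. Also open, going by these compounds, is whether the order seen at this one concentration would hold at other concentrations.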